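This account rests on a few compounds, and the source may have more. Where it says the series, first, only, none or still open, it means among the compounds named here.

Measured compounds in a functional assay on Caco-2 cells (Homo sapiens) for antiproliferative activity, read by sulforhodamine B assay, with a stated time of 2 days; on this read-out higher numbers stand for weaker inhibition of growth and lower numbers for stronger inhibition of growth:

Compound 1 `O=C(/C=C/c1ccccc1)NCCCCNc1ccnc2cc(Cl)ccc12` gives 24100 nM.
Compound 2 `O=C(/C=C/c1ccc(F)cc1)NCCCCNc1ccnc2cc(Cl)ccc12` gives 15000 nM.
Compound 3 `O=C(/C=C/c1ccccc1[N+](=O)[O-])NCCCCNc1ccnc2cc(Cl)ccc12` gives 11900 nM.

Compound 3 has the lowest of the three numbers. Its nearest neighbour is compound 2, and the gap between the two values is within the scatter, so no order can be read between them; the gap to compound 1 is beyond the scatter, and that step, a 2.0-fold lower number from compound 1 to compound 3 (0.31 log units; beyond the scatter), is modest in size.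

Compound 4 `O=C(/C=C/c1cccc([N+](=O)[O-])c1)NCCCCNc1ccnc2cc(Cl)ccc12` keeps the whole shared core and the same atoms; the change is 3-nitrophenyl in place of 2-nitrophenyl on a double-bonded chain carbon bound to a double-bonded chain carbon. Among the compounds with values here, no measured step moves a group from one place on this ring to another. The steps that come closest are a 2.0-fold lower number from compound 1 to compound 3 (0.31 log units; beyond the scatter), which shows what adding the nitro group did, and a 1.3-fold lower number from compound 2 to compound 3 (0.10 log units; within the scatter), which compares two different substituted rings and stays within the scatter. Together they suggest that changes on this ring shift the number only a little.

For compound 4 the expected step is therefore a 1.0-fold higher number from compound 3 to compound 4 (0.00 log units; within the scatter), not beyond the scatter. The estimate for compound 4 in this assay is 12000 nM, with a range from 6000 nM to 25000 nM.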

Compound 4, concentration for 50% growth inhibition: 19300 nM
Compound 4: the middle estimate sits 1.6-fold (0.21 log units) below what was measured; the measured number falls inside the stated range.
By their numbers in this assay, from the lowest: compounds 3, 2, 4 and 1 (each within the scatter of the next, the first and the last beyond it).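

In this assay, within the data shown here, moving the nitro group to another place on this ring gives a 1.6-fold higher number from compound 3 to compound 4 (0.21 log units; within the scatter), so the first change of place on this ring leaves two numbers that cannot be put in order. Among these compounds, the same holds when 3-nitrophenyl is set against the other rings: the comparison with 4-fluorophenyl gives a 1.3-fold higher number from compound 2 to compound 4 (0.11 log units; within the scatter), and the comparison with the unsubstituted ring gives a 1.2-fold lower number from compound 1 to compound 4 (0.10 log units; within the scatter), which means that the one step beyond the scatter seen so far, from the unsubstituted ring to 2-nitrophenyl, does not repeat with 3-nitrophenyl, although compound 3 and compound 4 themselves stay within the scatter of each other. Nothing available here offers an explanation for these numbers.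

On these data alone, what remains open is whether any group on this ring can move the number well beyond the scatter, for example an amine or a carboxylic acid in place of the nitro group. Also open, as far as these compounds go, is how much the chain matters, since a longer chain joining the amide to the shared core would test a part of the molecule that stays the same in all four compounds.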